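Swapping the sulfonyl aryl back to an amino group

The source may report more compounds than this note shows. Statements on the series, on what has been measured and on what is new or still open speak of the compounds shown alone.

The three measured compounds share one core. Compound 1 `CC(=O)OC[C@H]1O[C@H](NS(N)(=O)=O)C=C[C@@H]1OC(C)=O` gives 336000000 nM in a functional assay on HepG2 cells (Homo sapiens) for cytotoxicity, read by MTT assay, with a stated time of 48 h; a higher number here means a weaker inhibitor, a lower number a stronger inhibitor. Compound 2 `CC(=O)OC[C@H]1O[C@H](NS(=O)(=O)c2ccc(C)cc2)C=C[C@@H]1OC(C)=O` gives 157000000 nM, a change of a 2.1-fold lower number from compound 1 to compound 2 (0.33 log units; beyond the scatter). Compound 3 `CC(=O)OC[C@H]1O[C@H](NS(=O)(=O)c2ccc(C)cc2)C=C[C@H]1OC(C)=O` gives 307000000 nM; the step of a 2.0-fold higher number from compound 2 to compound 3 (0.29 log units; within the scatter) is attributed to the fact that compounds 2 and 3 differ only in the configuration as drawn. For the measured compounds named here, compound 3 therefore sits within the scatter of both compound 1 and compound 2, and no ordering among the three can be read beyond the one modest step.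

Compound 4 `CC(=O)OC[C@H]1O[C@H](NS(N)(=O)=O)C=C[C@H]1OC(C)=O` is not yet measured. It differs from compound 3 by amino in place of 4-methylphenyl on a sulfonyl sulfur. Going by the values given here, the step that bears on this is the one from compound 1 to compound 2, which went the opposite way and was a 2.1-fold lower number from compound 1 to compound 2 (0.33 log units; beyond the scatter); the present change reverses it on the other configuration of the core. A step of similar size, toward a higher number, is expected, a 2.1-fold higher number from compound 3 to compound 4 (0.32 log units; beyond the scatter). Compound 4 is estimated to give 640000000 nM in this assay, with a range from 300000000 nM to 1300000000 nM.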

Compound 4, half-maximal inhibitory concentration: 304000000 nM
Estimate against measurement, compound 4: 2.1-fold (0.32 log units) above; low and high end bracket the measured number.
By their numbers in this assay, from the lowest: compounds 2, 4, 3 and 1 (each within the scatter of the next, the first and the last beyond it).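

On the configuration of compound 3, amino in place of 4-methylphenyl on a sulfonyl sulfur gives a 1.0-fold lower number from compound 3 to compound 4 (0.00 log units; within the scatter) in this assay, so at this position the exchange of a single nitrogen for an aromatic ring leaves no readable step on this core. The modest step seen on the other configuration therefore did not recur, yet the two steps cannot be told apart: the same change on two cores in this assay, a 2.1-fold lower number (0.33 log units; beyond the scatter) from compound 1 to compound 2 and a 1.0-fold higher number (0.00 log units; within the scatter) from compound 4 to compound 3, 2.2-fold (0.33 log units) apart, within the scatter of two such steps. With amino on the sulfur, the drawn configuration also leaves no readable step, a 1.1-fold lower number from compound 1 to compound 4 (0.04 log units; within the scatter), and this pair isolates that one stereocentre: the fact that compounds 1 and 4 differ only in the configuration as drawn.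

The compounds shown leave open whether a methyl group or a longer alkyl chain on the sulfonyl sulfur would give a step beyond the scatter. They also leave open whether any such step would hold on both configurations of the shared core.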